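A Pyrrole in Place of Methoxy: Forecast for Compound 4

The compounds below may be only part of what the source reports. "The series", "measured", "known", "first", "only" and "open" are said of these compounds alone.

For the measured compounds named here, in a functional assay (trachea) with Rattus norvegicus as the target (a lower number here means a less potent compound, a higher number a more potent compound, by a factor of ten per unit of this negative logarithm), compound 1 `COc1ccc2c(c1)C(n1ccccc1=O)=CC(C)(C)O2` gives 5.99, the second highest of the three numbers measured so far. Compound 2 `CC1(C)C=C(n2ccccc2=O)c2cc(C(=O)c3ccccc3F)ccc2O1` gives 6.34, and compound 3 `CC1(C)C=C(n2ccccc2=O)c2cc(C(=N)NO)ccc2O1` gives 5.51. Compound 4 `Cc1ccc(C)n1-c1ccc2c(c1)C(n1ccccc1=O)=CC(C)(C)O2` differs from compound 1 in one place: 2,5-dimethyl-1H-pyrrol-1-yl in place of methoxy on an aromatic carbon. Two measured steps start from compound 1 and bear on this change. An entering group containing an aromatic ring brought a number 0.35 log units higher from compound 1 to compound 2 (beyond the scatter), whereas an entering group without a ring brought a number 0.48 log units lower from compound 1 to compound 3 (beyond the scatter). As the entering group of compound 4 again contains an aromatic ring, a modest rise is expected, a number 0.31 log units higher from compound 1 to compound 4 (beyond the scatter). Compound 4 is therefore estimated to give 6.3, with a range from 5.7 to 6.9.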

Compound 4, logarithm of the reciprocal of the active concentration, log(1/C): 6.78
Compound 4: middle estimate off by 0.48 log units, on the low side, within the range that was stated.
By their numbers in this assay, from the lowest: compound 3; then compound 1; then compound 2; then compound 4.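

In this assay, 2,5-dimethyl-1H-pyrrol-1-yl gives the most potent of the four compounds, with a number 0.79 log units higher from compound 1 to compound 4 (beyond the scatter), a number 0.44 log units higher from compound 2 to compound 4 (beyond the scatter) and a number 1.27 log units higher from compound 3 to compound 4 (beyond the scatter). This position therefore tolerates more than compound 2 showed, and a ring group without a carbonyl link can exceed (2-fluorophenyl)carbonyl. No measurement here accounts for the gain.

Left open is how an unsubstituted pyrrol-1-yl group, a phenyl or an amine would compare at this aromatic carbon. The compounds shown therefore do not separate the contribution of the two methyl groups from that of the pyrrole ring.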